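A few compounds are considered here, and "the series" means these few. Any claim that something is new, unique, unknown or untested is made for them only; others in the source may bear on it.

Measured compounds:
- compound 1, `O=C(/C=C/c1ccc(I)cc1)c1ccc(OCB(O)O)cc1`: 9500 nM
- compound 2, `O=C(/C=C/c1ccc(B(O)O)cc1)c1ccc(Cl)c(Cl)c1`: 5500 nM
- compound 3, `O=C(/C=C/c1ccc(B(O)O)cc1)c1ccc[nH]1`: 19000 nM

In a functional assay on MCF7 cells (Homo sapiens) for inhibition (a higher number here means a weaker inhibitor, a lower number a stronger inhibitor), compound 1 gives 9500 nM, the second highest of the three numbers. The nearest number is that of compound 2, and the furthest is that of compound 3, yet both of those gaps stay within the usual scatter, so the three compounds cannot be told apart on these numbers alone. All three share the chalcone-type core and each carries a boronic acid, though on different parts of the molecule.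

Compound 4, `O=C(O)COc1ccc(C(=O)/C=C/c2ccc(I)cc2)cc1`, has not been measured in this assay. It differs from compound 1 in one place: a group of 3 heavy atoms (1 carbon, 2 oxygen; no ring) in place of a group of 3 heavy atoms (1 boron, 2 oxygen; no ring), on a saturated chain carbon bound to an oxygen on an aromatic ring. Going by the values given here, no step between measured compounds isolates this kind of exchange, so nothing measured here shows what removing the boronic acid does.

The account therefore leans on the fact that every measured compound keeps a boronic acid. Compound 4 is expected to give a higher number than compound 1, with an estimated step from a 2.6-fold higher number from compound 1 to compound 4 (0.42 log units; beyond the scatter) that is likely beyond the scatter. For compound 4 the estimated value in this assay is 25000 nM, within a range from 7000 nM to 90000 nM.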

Compound 4, half-maximal inhibitory concentration: 9000 nM
Compound 4: middle estimate off by 2.8-fold (0.44 log units), on the high side; the range from low to high includes it.
By their numbers in this assay, from the lowest: compounds 2, 4, 1 and 3 (each within the scatter of the next, the first and the last beyond it).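

Putting carboxy in place of the group of boron and two oxygens, on a saturated chain carbon bound to an oxygen on an aromatic ring, gives a 1.1-fold lower number from compound 1 to compound 4 (0.02 log units; within the scatter) in this assay, so the two groups cannot be told apart at this position. Every earlier compound carried a boronic acid, so none could show whether inhibition at this level requires one; compound 4 has no boron, and this pair shows that, at this position and with the rest of compound 1 unchanged, the boronic acid is not required for a value at this level. No measurement accompanies the result that could explain why the two compounds match.

From the compounds shown here alone, it remains open whether an amine or a methyl ester at the same chain carbon would also leave the value in this assay unchanged, and whether a longer chain carrying the carboxy group would do so. Going by these compounds, it is also open whether carboxy could replace the boronic acid in compound 2 or compound 3, since this single pair says nothing about those compounds.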